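Three Ether and Ketone Analogues, and a Methoxy Successor

The compounds below may be only part of what the source reports. "The series", "measured", "known", "first", "only" and "open" are said of these compounds alone.

Compound 1 `CC(C)Oc1ccccc1OC(C)C1=NCCN1` gives 0.7 in an assay on CHO cells with Alpha-2C adrenergic receptor (Homo sapiens) as the target; on this read-out higher numbers stand for larger maximal responses and lower numbers for smaller maximal responses. Compound 2 `CC(Oc1ccccc1OC1CC1)C1=NCCN1` gives 0.7. Compound 3 `CC(=O)c1ccccc1OC(C)C1=NCCN1` gives 0.65.

All three numbers sit close together. The move from isopropyl to cyclopropyl on the ring oxygen left the read-out as it was, no change at the digits printed from compound 1 to compound 2 (within the scatter). Putting acetyl in the place of the alkoxy group on the aromatic carbon gave a number 0.050 lower from compound 1 to compound 3 (within the scatter) and a number 0.050 lower from compound 2 to compound 3 (within the scatter), so compound 3, though it carries the smallest of the three numbers, is separated from compound 1 and compound 2 by nothing beyond the usual scatter.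

Compound 4 `COc1ccccc1OC(C)C1=NCCN1` is the next compound to be measured. It differs from compound 3 in one place: methoxy in place of acetyl on an aromatic carbon. Both measured steps that bear on this change are those in which acetyl entered in place of an alkoxy group, and both stayed inside the scatter. The change from compound 3 to compound 4 runs the other way, with a smaller oxygen-bearing group taking the place of acetyl. Since compound 1 and compound 2 already show a number 0.050 lower from compound 1 to compound 3 (within the scatter) and a number 0.050 lower from compound 2 to compound 3 (within the scatter) as steps of no consequence, the return is expected to be equally small, a number 0.050 higher from compound 3 to compound 4 (within the scatter), with no movement beyond the scatter. Compound 4 is therefore estimated at 0.7, between 0.55 and 0.85.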

Compound 4, intrinsic activity: the largest response reached, as a fraction of the reference agonist's: 0.6
For compound 4 the middle estimate is 0.10 above the measured one; the measured number falls inside the stated range.
By their numbers in this assay, from the lowest: compounds 4, 3, 1 and 2 (each within the scatter of the next).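

In this assay, methoxy in place of acetyl on the aromatic carbon gave a number 0.050 lower from compound 3 to compound 4 (within the scatter), so this position has now held a ketone and three different ethers without a step between any two of them leaving the scatter. The new compound also brings the first methyl on that oxygen: methyl in place of cyclopropyl gave a number 0.10 lower from compound 2 to compound 4 (within the scatter), and methyl in place of isopropyl gave a number 0.10 lower from compound 1 to compound 4 (within the scatter), so these are the largest steps in the set, yet methyl, cyclopropyl and isopropyl on the oxygen still cannot be told apart on this read-out. No measurement on hand offers an explanation for any of these numbers.

From the compounds shown here alone, all four compounds carry an oxygen-bearing group at this place, so it remains open whether a group without oxygen, such as an amine, a chlorine atom or a plain butyl chain, would move the maximal response beyond the scatter. Going by these compounds, it also remains open whether a longer chain on the oxygen, such as butyl or benzyl, would stay as close to these four compounds as methyl, cyclopropyl and isopropyl do.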